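The source may report more compounds than this note shows. Statements on the series, on what has been measured and on what is new or still open speak of the compounds shown alone.

Compound 3 `O=S(=O)(c1ccc(F)c(Cl)c1)c1cnc2c(F)cccc2c1-c1ccc(F)cc1` gives 0.19 mL/min in an ADME assay on microsomes from liver (Homo sapiens) for metabolic stability, tested at 2.5 uM (a higher number here means faster removal of the compound, a lower number slower removal), the lowest of the three numbers recorded so far. Going by the values given here, compound 2 `O=S(=O)(c1ccc(F)c(F)c1)c1cnc2c(F)cccc2c1-c1cccc(Cl)c1` gives 1.13 mL/min in this assay, and compound 1 `O=S(=O)(c1ccc(F)c(F)c1)c1cnc2c(F)cccc2c1-c1cccc(F)c1` gives 1.28 mL/min in this assay; both stand well beyond the scatter above compound 3, and compounds 1 and 2 differ from compound 3 in two places, so no single step connects them to it.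

Compound 4 `O=S(=O)(c1ccc(F)c(F)c1)c1cnc2c(F)cccc2c1-c1ccc(F)cc1` differs from compound 3 in one place: fluoro in place of chloro on an aromatic carbon, the 3-chloro-4-fluorophenyl becoming a 3,4-difluorophenyl. Among the compounds with values here, the only measured step that swaps chloro and fluoro is a 1.1-fold lower number from compound 1 to compound 2 (0.05 log units; within the scatter), and it sits on the other aromatic ring and runs in the opposite direction, so it is a weak guide. It suggests the exchange itself may do little, yet compound 4 shares its 3,4-difluorophenyl sulfone with compounds 1 and 2, whose numbers lie far above compound 3. Weighing both, the number for compound 4 in this assay is expected to rise by a 3.7-fold higher number from compound 3 to compound 4 (0.57 log units; beyond the scatter), and compound 4 is estimated at 0.7 mL/min, within a range from 0.25 mL/min to 1.6 mL/min.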

Compound 4, intrinsic clearance in a liver preparation (reported as CLH), per the amount of preparation that the assay uses: 0.78 mL/min
Beside the measured number, compound 4's estimate is 1.1-fold (0.05 log units) below it, and the stated range covers the measured number.
By their numbers in this assay, from the lowest: compound 3; then compounds 4, 2 and 1 (each within the scatter of the next).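

Going by these compounds alone, on the 3-chloro-4-fluorophenyl, the exchange of chloro for fluoro at the carbon ortho to a fluoro group is a real step in this assay, a 4.1-fold higher number from compound 3 to compound 4 (0.61 log units; beyond the scatter), so this position responds to the change in a way the earlier compounds could not show. Swapping the aryl group on the other side of the core stays within the scatter, a 1.4-fold lower number from compound 2 to compound 4 (0.16 log units; within the scatter) and a 1.6-fold lower number from compound 1 to compound 4 (0.22 log units; within the scatter), which leaves the three compounds that carry the 3,4-difluorophenyl together and compound 3 apart from them. The same exchange of the two halogens therefore does not have one size wherever it stands: the same change on two cores in this assay, a 1.1-fold lower number (0.05 log units; within the scatter) from compound 1 to compound 2 and a 4.1-fold lower number (0.61 log units; beyond the scatter) from compound 4 to compound 3, 3.6-fold (0.56 log units) apart, beyond the scatter of two such steps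

The compounds shown leave open whether the low number of compound 3 follows from the chloro alone or from the chloro together with the 4-fluorophenyl, a pairing that appears only in compound 3. As far as these compounds go, how a methyl, a methoxy, a nitrile or an amine would read in this assay at the same carbon also remains open.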